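One More Methyl on Compounds Known Only by Limits

The source may hold more compounds than are shown below. What is called first, only, known or untested is meant among the compounds shown, and "the series" means these compounds.

Measured so far in an ADME assay on cells (Hepatocyte, Homo sapiens) for cytotoxicity, read by MTT assay, with a stated time of 48 h (a higher number here means that more compound is tolerated, a lower number that less compound is tolerated), with every value a limit:
- Compound 1 `COc1cc(NC(C)CCCNC(=O)c2c(C)[n+]([O-])c3ccccc3[n+]2[O-])c2ncccc2c1` gives > 212000 nM as its limit
- Compound 2 `COc1cc(NC(C)CCCNC(=O)c2c(C)[n+]([O-])c3ccc(OC)cc3[n+]2[O-])c2ncccc2c1` gives > 203000 nM as its limit
- Compound 3 `COc1cc(NC(C)CCCNC(=O)c2c(C)[n+]([O-])c3ccc(C)cc3[n+]2[O-])c2ncccc2c1` gives > 206000 nM as its limit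

In this assay compound 3 has only the limit > 206000 nM and no number. The two other values are limits as well, so the three compounds cannot be ranked against each other.

Compound 4 `COc1cc(NC(C)CCCNC(=O)c2c(C)[n+]([O-])c3cc(C)c(C)cc3[n+]2[O-])c2ncccc2c1` follows from compound 3 by one change, methyl in place of hydrogen on an aromatic carbon and the new group stands ortho to a methyl group.

The closest measured precedent is the same kind of replacement, which gave a step that the two limits leave unreadable from compound 1 to compound 3 and so offers no size to carry over. The methoxy replacement gave a step that the two limits leave unreadable from compound 1 to compound 2 and the exchange of methoxy for methyl gave a step that the two limits leave unreadable from compound 2 to compound 3 with neither adding a size. With no readable step in the series, no change beyond the usual scatter and no direction is expected in this assay for this replacement.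

The expected move is an at least 1.0-fold lower number from compound 3 to compound 4 (0.01 log units; that floor lies within the scatter) as an estimate. For compound 4 the estimated half-maximal cytotoxic concentration is 200000 nM with an expected range from 100000 nM to 400000 nM in this estimate. A report as a limit, and not as a number, is the likelier outcome.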

Compound 4, half-maximal cytotoxic concentration: > 202000 nM
Compound 4 was reported as a limit (the forecaster's own chance of this, stated with the estimate: 85%); at least 1.0-fold (0.00 log units) between middle value and limit.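

In this assay compound 4 gives > 202000 nM, a limit and not a number, and compound 3 is also known only by a limit, so the step between compound 3 and compound 4 cannot be read. The compounds shown leave open what actual concentration in this assay any of compounds 1 to 4 would give.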